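Swapping the pendant aryl group on a five-membered core

The compounds below may be only part of what the source reports. "The series", "measured", "known", "first", "only" and "open" are said of these compounds alone.

Compound 1 `CC(=O)N1N=C(c2ccc(-n3c(C)ccc3C)cc2)OC1c1cccc([N+](=O)[O-])c1`: 197000 nM
Compound 2 `CC(=O)N1N=C(c2ccc(-n3c(C)ccc3C)cc2)OC1c1ccc(Br)cc1`: 195000 nM

Of the compounds shown here, two sharing the same core have been measured in an ADME assay on A549 cells (Homo sapiens) for cytotoxicity, read by MTT assay, with a stated time of 72 h; a lower number here means a stronger inhibitor, a higher number a weaker inhibitor. Compound 1 gives 197000 nM in this assay, and compound 2 gives 195000 nM. Among the measured compounds shown here, the one measured step, a 1.0-fold lower number from compound 1 to compound 2 (0.00 log units; within the scatter), separates them, and compound 2 thus stands at the lowest of the two numbers, with compound 1 its only neighbour and the gap between them within the scatter.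

Compound 3 `CC(=O)N1N=C(c2ccc(-n3c(C)ccc3C)cc2)OC1c1ccccc1[N+](=O)[O-]` has not yet been measured in this assay. It differs from compound 2 by 2-nitrophenyl in place of 4-bromophenyl on a saturated ring carbon. For the measured compounds named here, the only step that bears on this change is the one from compound 1 to compound 2, in which a 3-nitrophenyl was exchanged for a 4-bromophenyl at the same saturated ring carbon and the number did not move beyond the scatter. A change at the same place, this time to a 2-nitrophenyl, is therefore expected to give a step of about no change at the digits printed from compound 2 to compound 3 (within the scatter) in this assay, that is, none beyond the scatter. Compound 3 is accordingly estimated at 195000 nM, with a range from 95000 nM to 400000 nM.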

Compound 3, half-maximal inhibitory concentration: 182000 nM
Estimate against measurement, compound 3: 1.1-fold (0.03 log units) above; measured number inside the range.
By their numbers in this assay, from the lowest: compounds 3, 2 and 1 (each within the scatter of the next).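

In this assay, exchanging 4-bromophenyl for 2-nitrophenyl on the saturated ring carbon gives a 1.1-fold lower number from compound 2 to compound 3 (0.03 log units; within the scatter), and exchanging 3-nitrophenyl for 2-nitrophenyl at the same carbon gives a 1.1-fold lower number from compound 1 to compound 3 (0.03 log units; within the scatter). The second step is the new kind of comparison: the earlier pair set a nitrophenyl against a bromophenyl, whereas compound 1 and compound 3 both carry a nitrophenyl and differ only in where the nitro group stands on that aryl ring, and this change also stays within the scatter, so all three aryl groups at this carbon now sit together in this assay. Nothing available on these compounds offers an explanation for this flat result.

Going by these compounds, all three compounds keep an aryl group with a single nitro or bromo substituent at this carbon, so it remains open whether a phenyl ring bearing an amine or a carboxylic acid, or a saturated cyclohexyl group, would move the number beyond the scatter. The acetyl group on the ring nitrogen is also the same throughout, which leaves open what a longer acyl chain at that place would do.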